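The compounds below may be only part of what the source reports. "The series", "measured", "known", "first", "only" and "open" are said of these compounds alone.

Measured compounds:
compound 1 `COCc1cc(=O)oc2cc(O)ccc12` — 5000 nM
compound 2 `O=c1cc(COc2ccccc2)c2ccc(O)cc2o1` — 10000 nM
compound 3 `CN(Cc1cc(=O)oc2cc(O)ccc12)c1ccccc1` — 6000 nM

In an assay on HeLa cells for inhibition of 17-beta-hydroxysteroid dehydrogenase type 3 (Homo sapiens) (on this read-out lower numbers stand for stronger inhibition and higher numbers for weaker inhibition), compound 1 gives the lowest of the three numbers, but compound 3 lies nearest to it within the scatter and compound 2, the furthest, is also within the scatter, so no order among the three is established. Compound 4 `O=c1cc(CSc2cccs2)c2ccc(O)cc2o1` differs from compound 1 by (thiophen-2-yl)sulfanyl in place of methoxy on a saturated chain carbon bound to an aromatic carbon. Among the compounds with values here, the only measured step touching this position is a 2.0-fold higher number from compound 1 to compound 2 (0.30 log units; within the scatter), within the scatter; it kept the oxygen, whereas here the oxygen leaves with the methyl. For the sulfur and the thiophene no comparison exists. The expectation for compound 4 in this assay is therefore a step of a 1.4-fold higher number from compound 1 to compound 4 (0.15 log units; within the scatter), no larger than the scatter. Compound 4 is estimated at 7000 nM, range 2500 nM to 20000 nM.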

Compound 4, half-maximal inhibitory concentration: 420 nM
Beside the measured number, compound 4's estimate is 17-fold (1.22 log units) above it; measured number outside the range, below it.
By their numbers in this assay, from the lowest: compound 4; then compounds 1, 3 and 2 (each within the scatter of the next).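

In this assay, within the data shown here, the saturated chain carbon bound to an aromatic carbon proves sensitive to its substituent, with (thiophen-2-yl)sulfanyl in place of methoxy giving a 12-fold lower number from compound 1 to compound 4 (1.08 log units; beyond the scatter), whereas the earlier compounds showed no step here beyond the scatter. This single change replaces the oxygen with sulfur and introduces the thiophene, so the contributions of the two cannot be separated. No evidence on hand bears on the origin of this step. Open, going by these compounds, is whether methylsulfanyl or phenylsulfanyl would match the (thiophen-2-yl)sulfanyl group. Also open, on these data alone, is how a thiophen-2-yloxy group or a longer chain would behave at this position.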